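Moving the Methyl Group from One Ring to Another

The source may hold more compounds than are shown below. What is called first, only, known or untested is meant among the compounds shown, and "the series" means these compounds.

In a functional assay on HCT-116 cells (Homo sapiens) for cytotoxicity, read by MTT assay, with a stated time of 48 h (on this read-out lower numbers stand for stronger inhibition and higher numbers for weaker inhibition), compound 1 `Nc1nc(-c2ccccc2)cn1/N=C/c1cc2ccccc2nc1Cl` gives 6920 nM. Compound 2 `Cc1ccc(-c2cn(/N=C/c3cc4ccccc4nc3Cl)c(N)n2)cc1` reports only a limit in this assay, > 50000 nM. The change from compound 1 to compound 2 is methyl in place of hydrogen on an aromatic carbon, and it brings an at least 7.2-fold higher number from compound 1 to compound 2 (0.85 log units; beyond the scatter); the step is an at-least figure because compound 2 sits at the limit of > 50000 nM in this assay, at which 1 of the 3 values shown sits. Compound 3 `Nc1nc(-c2cccc3ccccc23)cn1/N=C/c1cc2ccccc2nc1Cl` gives 6340 nM in this assay, a number within the scatter of compound 1; how the core of compound 3 differs from that of compound 1 is not broken down here. Compound 4 `Cc1ccc2nc(Cl)c(/C=N/n3cc(-c4cccc5ccccc45)nc3N)cc2c1` is not yet measured. It differs from compound 3 by methyl in place of hydrogen on an aromatic carbon. This is the same kind of change as that from compound 1 to compound 2, but not the same: there the methyl entered on a six-membered aromatic ring of carbon only, para to a large group, whereas here it enters on a ring that is part of a fused or bridged system of two rings, meta to a fused ring and para to a fused ring. Among the compounds with values here, only one such step is measured, and on another ring, so the expectation rests on it loosely. From compound 3 to compound 4 a step of a 2.4-fold higher number from compound 3 to compound 4 (0.37 log units; beyond the scatter) is expected in this assay. Compound 4 is therefore estimated at 15000 nM, within 4000 nM to 60000 nM.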

Compound 4, half-maximal inhibitory concentration: 5840 nM
Estimate against measurement, compound 4: 2.6-fold (0.41 log units) above; low and high end bracket the measured number.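

In this assay, methyl in place of hydrogen on the ring that is part of a fused or bridged system of two rings brought a 1.1-fold lower number from compound 3 to compound 4 (0.04 log units; within the scatter), so on this core the change left no mark that can be told from the scatter. Set beside the earlier step, on a six-membered aromatic ring of carbon only, the same change did not carry over from one core to the other: the same change on two cores in this assay, an at least 7.2-fold higher number (0.85 log units; beyond the scatter) from compound 1 to compound 2 and a 1.1-fold lower number (0.04 log units; within the scatter) from compound 3 to compound 4, at least 7.8-fold (0.89 log units) apart, beyond the scatter of two such steps

The methyl stands on a different ring in each pair, so this does not show whether the ring bearing it or the rest of the core sets the two steps apart, and the earlier step ends at a limit rather than a number: the limit of > 50000 nM in this assay, at which 1 of the 4 values shown sits.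

The compounds shown leave open what a methyl would do at the place it holds in compound 4 on the core of compound 1. They also leave open whether a methoxy group or an amine at that same place would move the number at all.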